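The compounds below may be only part of what the source reports. "The series", "measured", "known", "first", "only" and "open" are said of these compounds alone.

Measured so far in a functional assay on MCF7 cells (Homo sapiens) for antiproliferative activity, read by sulforhodamine B assay, with a stated time of 48 h; a higher number here means a weaker inhibitor, a lower number a stronger inhibitor:
- compound 1 `O=C1NCCN1c1ccc(S(=O)(=O)Nc2ccc(F)c(F)c2)cc1` gives 620 nM
- compound 2 `CC(C)Cc1ccc(NS(=O)(=O)c2ccc(N3CCNC3=O)cc2)cc1` gives > 1000 nM, which is a limit of the assay and not a number
- compound 3 `Cc1cccc(NS(=O)(=O)c2ccc(N3CCNC3=O)cc2)c1` gives 190 nM

Compound 3 holds the lowest of the two numbers shown. Going by the values given here, the one measured step that reaches it is a 3.3-fold lower number from compound 1 to compound 3 (0.51 log units; beyond the scatter), a swap of the aryl group on the sulfonamide nitrogen. Compound 2 sits at the limit of > 1000 nM in this assay, at which 1 of the 3 values shown sits.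

Compound 4 `O=C1NCCN1c1ccc(S(=O)(=O)Nc2ccc(Cl)cc2)cc1` differs from compound 3 by 4-chlorophenyl in place of 3-methylphenyl on a sulfonamide nitrogen. Among the compounds with values here, the only comparable aryl swap moved the number modestly, so a modest rise toward the value of compound 1 is expected here, a 2.4-fold higher number from compound 3 to compound 4 (0.37 log units; beyond the scatter). Compound 4 is therefore estimated at 450 nM, within a range from 150 nM to 1400 nM.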

Compound 4, half-maximal inhibitory concentration: 170 nM
The estimate for compound 4 lay 2.6-fold (0.42 log units) above the measured number; measured number inside the range.
By their numbers in this assay, from the lowest: compounds 4 and 3 (each within the scatter of the next); then compound 1. At a limit, above all of these: compound 2.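

In this assay, two different groups on the sulfonamide nitrogen give values that cannot be told apart, with a 1.1-fold lower number from compound 3 to compound 4 (0.05 log units; within the scatter), so this place accepts both 3-methylphenyl and 4-chlorophenyl. The 3,4-difluorophenyl group of compound 1 stands clearly apart, with a 3.6-fold lower number from compound 1 to compound 4 (0.56 log units; beyond the scatter). Compound 2 stands at a limit and not a number, so an at least 5.8-fold lower number from compound 2 to compound 4 (0.76 log units; beyond the scatter) gives only a minimum size for that change: the limit of > 1000 nM in this assay, at which 1 of the 4 values shown sits.

On these data alone, what an amine or a carboxylic acid on this aromatic ring would do remains open. So does the effect of an ethyl group, a chain that lies in size between methyl and isobutyl.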